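The compounds below may be only part of what the source reports. "The series", "measured", "known", "first", "only" and "open" are said of these compounds alone.

In a functional assay on A549 cells (Homo sapiens) for inhibition, read by MTT assay, with a stated time of 72 h (on this read-out higher numbers stand for weaker inhibition and lower numbers for stronger inhibition), compound 1 `COc1ccc(/C=C/C(=O)c2c(OC)cc(O)c(CC=C(C)C)c2O)cc1` gives 38000 nM, compound 2 `COc1cc(/C=C/C(=O)c2c(OC)cc(O)c(CC=C(C)C)c2O)ccc1O` gives 11800 nM and compound 3 `COc1ccccc1/C=C/C(=O)c1c(OC)cc(O)c(CC=C(C)C)c1O` gives 12500 nM. Compound 3 therefore sits level with compound 2, with a 1.1-fold higher number from compound 2 to compound 3 (0.03 log units; within the scatter), and clearly under compound 1, with a 3.0-fold lower number from compound 1 to compound 3 (0.48 log units; beyond the scatter). Compound 4 `COc1cc(O)c(CC=C(C)C)c(O)c1C(=O)/C=C/c1ccc(Cl)cc1` differs from compound 3 in one place: 4-chlorophenyl in place of 2-methoxyphenyl on a double-bonded chain carbon bound to a double-bonded chain carbon. Changes at this same place have been modest so far, with a 3.2-fold lower number from compound 1 to compound 2 (0.51 log units; beyond the scatter) as well as the step to compound 3. Among the compounds with values here, no compound with 4-chlorophenyl has been measured, so no step beyond the scatter is expected, with only a slight lean towards the higher number of compound 1. The expected change is a 1.4-fold higher number from compound 3 to compound 4 (0.13 log units; within the scatter). For compound 4, the estimate is 17000 nM, within an expected range of 7000 nM to 40000 nM.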

Compound 4, half-maximal inhibitory concentration: 11800 nM
Beside the measured number, compound 4's estimate is 1.4-fold (0.16 log units) above it, and the stated range covers the measured number.
By their numbers in this assay, from the lowest: compounds 2, 4 and 3 (each within the scatter of the next); then compound 1.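

Swapping in 4-chlorophenyl, a ring with no hydrogen-bond acceptor, gives a 1.1-fold lower number from compound 3 to compound 4 (0.03 log units; within the scatter) and no change at the digits printed from compound 2 to compound 4 (within the scatter), so this place accepts a ring without oxygen as readily as the two oxygen-bearing rings of those compounds. Chloro in place of methoxy on an aromatic carbon gives a 3.2-fold lower number from compound 1 to compound 4 (0.51 log units; beyond the scatter), the same distance from compound 1 that compounds 2 and 3 show. Nothing available explains why compound 1 stands apart.

Still open, on these data alone, is whether a ring carrying an amine or a carboxylic acid at this place would shift the number. Also open, as far as these compounds go, is whether 2-chlorophenyl would match 4-chlorophenyl.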